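This account rests on a few compounds, and the source may have more. Where it says the series, first, only, none or still open, it means among the compounds named here.

Measured in a functional assay on A549 cells (Homo sapiens) for cytotoxicity, read by MTT assay, with a stated time of 48 h; on this read-out higher numbers stand for weaker inhibition and lower numbers for stronger inhibition:
- compound 1 `COc1c(OCCCCN2CCNCC2)cc(O)c2c(=O)cc(-c3ccccc3)oc12`: 1740 nM
- compound 2 `O=c1cc(-c2ccccc2)oc2c(OCCCN3CCCC3)c(O)cc(O)c12`: > 100000 nM

For compound 2, > 100000 nM is a limit of the assay and not a number. Within the data shown here, compound 1 holds the only number (1740 nM). Compound 3 `COc1c(OCCCN2CCN(C)CC2)cc(O)c2c(=O)cc(-c3ccccc3)oc12` has the same atoms as compound 1, joined differently, with 4-methylpiperazin-1-yl in place of (piperazin-1-yl)methyl on a saturated chain carbon, three bonds along the chain from an oxygen on an aromatic ring. Among the measured compounds shown here, no measured step bears on this change, so none beyond the scatter is expected in this assay, the estimated step being a 1.7-fold higher number from compound 1 to compound 3 (0.24 log units; within the scatter). For compound 3 the estimated value is 3000 nM, with an expected range of 900 nM to 15000 nM.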

Compound 3, half-maximal inhibitory concentration: 9900 nM
The estimate for compound 3 lay 3.3-fold (0.52 log units) below the measured number; the range from low to high includes it.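

In this assay the change reads as a 5.7-fold higher number from compound 1 to compound 3 (0.76 log units; beyond the scatter), so at this position the assay separates 4-(piperazin-1-yl)butyl from 3-(4-methylpiperazin-1-yl)propyl, although the two have the same atoms. Before compound 3, no measured step bore on this position. Nothing given here accounts for the step.

Still open, as far as these compounds go, is how a 3-(piperazin-1-yl)propyl or a 4-(4-methylpiperazin-1-yl)butyl group would read on the same core. Either would separate the chain length from the methyl on the piperazine.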